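This account rests on a few compounds, and the source may have more. Where it says the series, first, only, none or still open, it means among the compounds named here.

Measured compounds in a functional assay on HEK293 cells for antagonist activity at Voltage-dependent L-type calcium channel subunit alpha-1D (Rattus norvegicus), read by FLIPR; on this read-out higher numbers stand for weaker inhibition and lower numbers for stronger inhibition:
compound 1 `CCOC(=O)C1=C(C)NC(CO)=C(C(=O)OCC)C1c1cccc([N+](=O)[O-])c1` gives 45 nM
compound 2 `CCOC(=O)C1=C(C)NC(CCl)=C(C(=O)OCC)C1c1cccc([N+](=O)[O-])c1` gives 53 nM
compound 3 `CCOC(=O)C1=C(C)NC(/C=C/C#N)=C(C(=O)OCC)C1c1cccc([N+](=O)[O-])c1` gives 45 nM

Compound 3 stands level with compound 1, the two together at the lowest numbers of the three; the step of a 1.2-fold lower number from compound 2 to compound 3 (0.07 log units; within the scatter) lies inside the scatter. All three measured steps, a 1.2-fold higher number from compound 1 to compound 2 (0.07 log units; within the scatter), no change at the digits printed from compound 1 to compound 3 (within the scatter) and a 1.2-fold lower number from compound 2 to compound 3 (0.07 log units; within the scatter), vary the group on the double-bonded ring carbon of the shared core and none of them moved this assay beyond its scatter.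

Compound 4 `CCOC(=O)C1=C(C)NC(/C=C/c2ccc([N+](=O)[O-])cc2)=C(C(=O)OCC)C1c1cccc([N+](=O)[O-])c1` differs from compound 3 by 4-nitrophenyl in place of cyano on a double-bonded chain carbon bound to a double-bonded chain carbon. For the measured compounds named here, no measured step exchanges the terminal group of the 2-cyanoethenyl chain, so the three steps bear on it only by showing that changes at this side of the core have left this assay flat. The step of no change at the digits printed from compound 3 to compound 4 (within the scatter) is therefore expected to stay within the scatter. Compound 4 is estimated at 45 nM, range 15 nM to 135 nM.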

Compound 4, half-maximal inhibitory concentration: 2060 nM
Estimate against measurement, compound 4: 46-fold (1.66 log units) below, outside the stated range (above it).
By their numbers in this assay, from the lowest: compounds 1, 3 and 2 (each within the scatter of the next); then compound 4.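

In this assay, for the compounds shown here, the exchange at the end of the ethenyl chain gives a 46-fold higher number from compound 3 to compound 4 (1.66 log units; beyond the scatter) and is the first change on this side of the shared core to go beyond the scatter. Against the other two groups the picture is the same, with a 39-fold higher number from compound 2 to compound 4 (1.59 log units; beyond the scatter) for chloromethyl and a 46-fold higher number from compound 1 to compound 4 (1.66 log units; beyond the scatter) for hydroxymethyl, so the flat readings of 2-cyanoethenyl, chloromethyl and hydroxymethyl do not extend to 2-(4-nitrophenyl)ethenyl. Nothing available explains this loss of inhibition.

As far as these compounds go, whether the loss follows the nitro group or the aromatic ring itself stays open. A plain phenyl or a 4-aminophenyl at the chain end would separate the two.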